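The compounds below may be only part of what the source reports. "The series", "measured", "known", "first", "only" and "open" are said of these compounds alone.

Compounds measured in an assay on mitochondria from L6 cells (Rattus norvegicus) for activation, with a stated time of 90 min; on this read-out higher numbers stand for an effect only at larger amounts of compound and lower numbers for an effect already at smaller amounts:

compound 1 `Fc1ccccc1Nc1nc2nonc2nc1NC1CCCCC1` gives 13400 nM
compound 2 `Fc1ccccc1Nc1nc2nonc2nc1Nc1cccc(F)c1F` gives 500 nM
compound 3 `Cc1ccc(Nc2nc3nonc3nc2Nc2ccccc2F)cc1` gives 2100 nM

Compound 3 stands second highest among the three numbers. Its nearest neighbour is compound 2, and the step of a 4.2-fold higher number from compound 2 to compound 3 (0.62 log units; beyond the scatter) marks it as beyond the scatter; its furthest is compound 1, where the step of a 6.4-fold lower number from compound 1 to compound 3 (0.80 log units; beyond the scatter) was reached by exchanging the cyclohexyl for an aromatic ring.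

Compound 4 `Fc1ccccc1Nc1nc2nonc2nc1Nc1ccccn1` carries the change pyridin-2-yl in place of 4-methylphenyl on a nitrogen on an aromatic ring

Within the data shown here, no measured pair tests a ring bearing a hetero atom, so the expectation rests on two steps that touch the same nitrogen. Both aromatic rings so far lowered the number relative to the cyclohexyl of compound 1, the step of a 27-fold lower number from compound 1 to compound 2 (1.43 log units; beyond the scatter) being the larger. The pyridin-2-yl keeps an aromatic six-membered ring at that position, and the smaller swing a 4.2-fold higher number from compound 2 to compound 3 (0.62 log units; beyond the scatter) shows how much the substitution pattern on that ring can move the number. The step of a 1.4-fold lower number from compound 3 to compound 4 (0.15 log units; within the scatter) is therefore expected to be small, at most modest, and not clearly beyond the scatter. Compound 4 is estimated at 1500 nM, with a range from 400 nM to 6000 nM.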

Compound 4, half-maximal effective concentration: 9000 nM
Beside the measured number, compound 4's estimate is 6.0-fold (0.78 log units) below it, outside the stated range (above it).
By their numbers in this assay, from the lowest: compound 2; then compound 3; then compounds 4 and 1 (each within the scatter of the next).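

In this assay, an aromatic six-membered ring on this nitrogen does not by itself keep the number low: the result gives a 4.3-fold higher number from compound 3 to compound 4 (0.63 log units; beyond the scatter) and, against the best compound shown, an 18-fold higher number from compound 2 to compound 4 (1.26 log units; beyond the scatter) as steps that both run upward. The step of a 1.5-fold lower number from compound 1 to compound 4 (0.17 log units; within the scatter) lies within the scatter, so compound 4 stands level with the cyclohexyl of compound 1 and goes against the lower numbers that compound 2 and compound 3 had suggested for aromatic rings at this place. The change removes a carbon-only ring with its methyl group and brings in a ring with one hetero atom and one hydrogen-bond acceptor, and no measurement at hand bears on which of these differences lies behind the step.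

The compounds shown leave open whether the ring nitrogen itself or the missing methyl group matters more, a question that a plain phenyl or a 4-methylpyridin-2-yl on the same nitrogen would address. They also leave open whether the position of the ring nitrogen counts, as pyridin-3-yl or pyridin-4-yl would show, and how a ring carrying an amine or a carboxylic acid would read.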